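Trading trifluoromethyl for bromo in a cell assay

The source may hold more compounds than are shown below. What is called first, only, known or untested is meant among the compounds shown, and "the series" means these compounds.

Among the measured compounds shown here, in an ADME assay on L6 cells (Rattus norvegicus) for cytotoxicity, read by resazurin assay, with a stated time of 72 h (on this read-out higher numbers stand for weaker inhibition and lower numbers for stronger inhibition), compound 1 (`OC(c1ccc(Cl)cc1)(c1cccnc1)c1ccc(F)cc1F`) gives 70200 nM and compound 2 (`OC(c1ccc(Cl)cc1)(c1cccnc1)c1ccc(C(F)(F)F)cc1F`) gives 57400 nM so compound 2 lies within the scatter of its only neighbour. Compound 3 (`OC(c1ccc(Cl)cc1)(c1cccnc1)c1ccc(Br)cc1F`) is still unmeasured and carries bromo in place of trifluoromethyl on an aromatic carbon. For the measured compounds named here, the only measured step bearing on this, trifluoromethyl in place of fluoro on an aromatic carbon (a 1.2-fold lower number from compound 1 to compound 2 (0.09 log units; within the scatter)), stayed within the scatter, so no step beyond the scatter is expected in this assay here. The expected step is therefore small (a 1.0-fold higher number from compound 2 to compound 3 (0.02 log units; within the scatter)). Compound 3 is estimated at 60000 nM (expected range 30000 nM to 115000 nM).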

Compound 3, half-maximal inhibitory concentration: 79200 nM
Compound 3: the middle estimate sits 1.3-fold (0.12 log units) below what was measured; measured number inside the range.
By their numbers in this assay, from the lowest: compounds 2, 1 and 3 (each within the scatter of the next).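

Bromo now joins trifluoromethyl and fluoro at this position, and all three groups lie within the scatter of one another in this assay: bromo reads the same within the scatter against trifluoromethyl (a 1.4-fold higher number from compound 2 to compound 3 (0.14 log units; within the scatter)) and against fluoro (a 1.1-fold higher number from compound 1 to compound 3 (0.05 log units; within the scatter)). Even one heavy atom entering where four leave does not carry the number beyond the scatter. Nothing measured here says why these groups read alike. On these data alone, whether an amine or a carboxylic acid at this position would give a step beyond the scatter remains open.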